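Aminoquinone series: aryl group replacement at the ring carbon

A few compounds are considered here, and "the series" means these few. Any claim that something is new, unique, unknown or untested is made for them only; others in the source may bear on it.

Compound 1 `COC1=C(N)C(=O)c2c(ccnc2-c2ccccn2)C1=O` stands highest of the two numbers in hand. In a functional assay on the whole organism for inhibition, with Lepidium sativum as the target (on this read-out higher numbers stand for weaker inhibition and lower numbers for stronger inhibition), compound 1 gives 12700 nM. Compound 2 `COC1=C(N)C(=O)c2c(ccnc2-c2ccccc2[N+](=O)[O-])C1=O` is the nearest neighbour; in this assay compound 2 gives 6030 nM, a lower number than compound 1 and beyond the scatter, so compound 2 inhibits more strongly. Among the measured compounds shown here, no pair of measured compounds differs in a single place, so no measured step is available for the series.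

Compound 3 `COC1=C(N)C(=O)c2c(ccnc2-c2ccc(N)cc2)C1=O` is not yet measured. It differs from compound 1 by 4-aminophenyl in place of pyridin-2-yl on an aromatic carbon. For the measured compounds named here, with no matched step to lean on, a moderate move toward a lower number is expected, of roughly the size seen between compound 1 and compound 2, though a result within the scatter is also plausible. For compound 3 the expected step in this assay is a 1.8-fold lower number from compound 1 to compound 3 (0.26 log units; within the scatter). Compound 3 is estimated at 7000 nM, within a range from 2500 nM to 25000 nM.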

Compound 3, half-maximal inhibitory concentration: 15500 nM
Beside the measured number, compound 3's estimate is 2.2-fold (0.35 log units) below it; the range from low to high includes it.
By their numbers in this assay, from the lowest: compound 2; then compounds 1 and 3 (each within the scatter of the next).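

In this assay, among the compounds shown here, the first single-place step reads a 1.2-fold higher number from compound 1 to compound 3 (0.09 log units; within the scatter), with 4-aminophenyl in place of pyridin-2-yl on the aromatic carbon next to the ring nitrogen. At this position, then, a six-membered aromatic ring with a hetero atom gives way to a carbon-only ring carrying an amino group and a hydrogen-bond donor, and the read-out stays within the scatter. Nothing on hand gives a reason for this result.

Two changes travel together in this step, the loss of the pyridine nitrogen and the gain of the amino group, so the compounds shown cannot say whether each alone is neutral or whether the two offset each other. A plain phenyl group at this position would separate them.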